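The source may hold more compounds than are shown below. What is called first, only, known or untested is meant among the compounds shown, and "the series" means these compounds.

The measured compounds:
compound 1, `COc1cc(/C=C/C(=O)C2=C(/C=C/c3ccc(O)c(OC)c3)NC(=O)NC2c2ccc(C)cc2)ccc1O`, 23.9%
compound 2, `COc1cc(/C=C/C(=O)C2=C(/C=C/c3ccc(O)c(OC)c3)NC(=O)NC2c2ccccc2O)ccc1O`, 71%
compound 3, `COc1cc(/C=C/C(=O)C2=C(/C=C/c3ccc(O)c(OC)c3)NC(=S)NC2c2ccc(C)cc2)ccc1O`, 19.9%

In a functional assay, with a stated time of 20 min, tested at 10 uM (on this read-out lower numbers stand for a weaker effect and higher numbers for a stronger effect at the one concentration tested), compound 1 gives 23.9% and compound 2 gives 71%. The two share one core and differ in a single place: 2-hydroxyphenyl in place of 4-methylphenyl on a saturated ring carbon. This change made a step of a number 47.1 percentage points higher from compound 1 to compound 2 (beyond the scatter).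

Compound 3 gives 19.9% in this assay. How its core differs from the core of compound 1 is not broken down here; the values of compound 1 and compound 3 lie within the scatter of each other, so nothing is said about which is stronger.

Compound 4, `COc1cc(/C=C/C(=O)C2=C(/C=C/c3ccc(O)c(OC)c3)NC(=S)NC2c2ccccc2O)ccc1O`, has not yet been measured. It relates to compound 3 as compound 2 relates to compound 1: 2-hydroxyphenyl in place of 4-methylphenyl on a saturated ring carbon. The place of the change reads the same in both pairs, so it is the same change. Because the earlier step was a number 47.1 percentage points higher from compound 1 to compound 2 (beyond the scatter), a step of about the same size is expected here, estimated at a number 45.1 percentage points higher from compound 3 to compound 4 (beyond the scatter). A single earlier example is the only ground for this, so the range is kept wide. Compound 4 is expected to give 65%, with a range from 40% to 85%.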

Compound 4, a percentage reported as activity, at one concentration (the size of the read-out at that concentration, not a potency): 70.8%
Estimate against measurement, compound 4: 5.8 percentage points below; measured number inside the range.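

In this assay, putting 2-hydroxyphenyl in place of 4-methylphenyl on the saturated ring carbon gave a number 50.9 percentage points higher from compound 3 to compound 4 (beyond the scatter) on the core that carries the thiocarbonyl-type difference printed in its structure, and this large rise sits well with the earlier one on the core of compound 1. The two steps do not differ: the same change on two cores in this assay, a number 47.1 percentage points higher (beyond the scatter) from compound 1 to compound 2 and a number 50.9 percentage points higher (beyond the scatter) from compound 3 to compound 4, 3.8 percentage points apart, within the scatter of two such steps. Within the data shown here, this shows that the change carried from one core to the other with its size kept, but it rests on only two cores and a single concentration, so it neither explains the rise nor promises the same on any further core.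

The compounds shown hold only 4-methylphenyl and 2-hydroxyphenyl on that carbon, so it stays open what a plain phenyl, a methoxyphenyl or an aminophenyl would give there. Also open is how the effects of these compounds compare at any other concentration: each has a reading at one concentration only.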